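Thiophen-2-yl in place of naphthalen-1-yl: the expected step

This account rests on a few compounds, and the source may have more. Where it says the series, first, only, none or still open, it means among the compounds named here.

Measured so far in a functional assay on HT-29 cells (Homo sapiens) for inhibition, read by MTT assay, with a stated time of 48 h; a higher number here means a weaker inhibitor, a lower number a stronger inhibitor
- compound 1 `COc1cc(-c2cc(-c3ccc(Br)cc3)nc(-c3ccccc3)n2)cc(OC)c1OC` gives 3170 nM
- compound 2 `COc1cc(-c2cc(-c3cccc4ccccc34)nc(-c3ccccc3)n2)cc(OC)c1OC` gives 4730 nM

Compound 2 stands within the scatter of compound 1, so the two numbers cannot be ranked. For the measured compounds named here, the one measured step of a 1.5-fold higher number from compound 1 to compound 2 (0.17 log units; within the scatter) is naphthalen-1-yl in place of 4-bromophenyl on an aromatic carbon, and it stays within the scatter. Compound 3 `COc1cc(-c2cc(-c3cccs3)nc(-c3ccccc3)n2)cc(OC)c1OC` changes the same place again, with thiophen-2-yl in place of naphthalen-1-yl on an aromatic carbon while the rest of the core is kept. Going by the values given here, no measured compound yet carries thiophen-2-yl, so only that single step bears on this change. In this assay no shift beyond the scatter is therefore expected, and no direction is firmly supported. The estimated step of a 1.2-fold lower number from compound 2 to compound 3 (0.07 log units; within the scatter) is expected to remain small. For compound 3 the estimated value is 4000 nM with an expected range from 1800 nM to 9000 nM in this series.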

Compound 3, half-maximal inhibitory concentration: > 25000 nM
Compound 3: no number, only a limit; the forecaster's own chance of this, stated with the estimate: 10%; middle value at least 6.2-fold (0.79 log units) away from the limit.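

In this assay, the aromatic carbon carrying these groups proves sensitive to the group it bears, which the pair of compound 1 and compound 2 could not show: thiophen-2-yl gives an at least 5.2-fold higher number from compound 2 to compound 3 (0.72 log units; beyond the scatter) and an at least 7.8-fold higher number from compound 1 to compound 3 (0.89 log units; beyond the scatter). Compound 3 is therefore a weaker inhibitor than both earlier compounds, although the reading for compound 3 is a limit and not a number, so the full size of both steps stays unknown: the limit of > 25000 nM in this assay, at which 1 of the 3 values shown sits.

The three compounds do not separate the smaller five-membered aromatic ring from its sulfur, as thiophen-2-yl differs from the other two groups in both. On these data alone, whether furan-2-yl, thiophen-3-yl or a 4-aminophenyl group would stay with compound 1 and compound 2 or fall with compound 3 remains open.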